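Swapping a benzyl-type aryl for a furan in compound 3

The source may hold more compounds than are shown below. What is called first, only, known or untested is meant among the compounds shown, and "the series" means these compounds.

Measured so far:
- compound 1, `COc1ccc2[nH]c3c(c2c1)CCNC31CCN(Cc2ccccc2Cl)CC1`: 2200 nM
- compound 2, `COc1ccc2[nH]c3c(c2c1)CCNC31CCN(Cc2ccc(F)c(F)c2F)CC1`: 4100 nM

Both compounds share one core and differ only in the aromatic ring on the saturated chain carbon bound to the amine nitrogen in a ring. In an assay on FRT cells for positive allosteric modulation of Cystic fibrosis transmembrane conductance regulator variant N1303K (Homo sapiens), in the presence of a further agent that is not named here (a higher number here means that more compound is needed for the effect, a lower number that less compound is needed), compound 1 gives 2200 nM, and compound 2 gives 4100 nM. The step of a 1.9-fold higher number from compound 1 to compound 2 (0.27 log units; within the scatter) is within the scatter, so the two compounds cannot be told apart on these numbers; compound 2 simply carries the higher of the two figures.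

Compound 3, `COc1ccc2[nH]c3c(c2c1)CCNC31CCN(Cc2ccco2)CC1`, has not been measured. It differs from compound 2 in one place: furan-2-yl in place of 2,3,4-trifluorophenyl on a saturated chain carbon bound to an amine nitrogen in a ring. Among the compounds with values here, no measured step covers an exchange of a six-membered carbon ring for a five-membered ring with an oxygen. Within the data shown here, the only measured step, an exchange of one aromatic ring for another at the same place, was within the scatter. On that basis no movement beyond the scatter is expected for compound 3, and the expected step is a 1.0-fold lower number from compound 2 to compound 3 (0.01 log units; within the scatter). The estimate for compound 3 in this assay is 4000 nM, with a range from 1300 nM to 12000 nM.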

Compound 3, half-maximal effective concentration: 16400 nM
Beside the measured number, compound 3's estimate is 4.1-fold (0.61 log units) below it, outside the stated range (above it).
By their numbers in this assay, from the lowest: compounds 1 and 2 (each within the scatter of the next); then compound 3.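

In this assay, the change to furan-2-yl gives a 4.0-fold higher number from compound 2 to compound 3 (0.60 log units; beyond the scatter), and measured against the 2-chlorophenyl compound it gives a 7.5-fold higher number from compound 1 to compound 3 (0.87 log units; beyond the scatter). This shows that the place on a saturated chain carbon bound to an amine nitrogen in a ring does respond to the choice of aromatic ring, which the step between the two halogen-carrying rings could not show. Those two six-membered rings of carbon only remain within the scatter of each other, while the five-membered ring with an oxygen stands apart from both, although three compounds are a narrow base and nothing measured here bears on what lies behind this step.

The change alters several things at once: the ring size, the presence of an oxygen, the number of heavy atoms and the loss of the halogens, and the compounds shown do not separate these. Going by these compounds, it stays open how a plain phenyl, a thiophene or a pyridine would read at this place, and these three rings would help show which of those differences matters.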